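The source may report more compounds than this note shows. Statements on the series, on what has been measured and on what is new or still open speak of the compounds shown alone.

Compound 3 `CCOc1ccccc1CNc1nc(Cl)nc2c1ncn2[C@H]1[C@H](O)[C@H](O)[C@@H]2C[C@@H]21` gives 15.2 nM in an assay on CHO cells for displacement of a labelled ligand from adenosine receptor A3 (Homo sapiens), with a stated time of 60 min (a higher number here means a weaker inhibitor, a lower number a stronger inhibitor), where it holds the second highest number of the three measured compounds. Its nearest neighbour is compound 2 `O[C@@H]1[C@H](O)[C@@H]2C[C@@H]2[C@H]1n1cnc2c(NCCCF)nc(Cl)nc21`, which gives 32.4 nM in this assay; the step between them is a 2.1-fold lower number from compound 2 to compound 3 (0.33 log units; beyond the scatter). Furthest from it is compound 1 `O[C@@H]1[C@H](O)[C@@H]2C[C@@H]2[C@H]1n1cnc2c(NC3CCC3)nc(Cl)nc21`, which gives 5.9 nM in this assay, the lowest number of the three.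

Compound 4 `O[C@@H]1[C@H](O)[C@@H]2C[C@@H]2[C@H]1n1cnc2c(NCc3cc(F)ccc3F)nc(Cl)nc21` is the next member: 2,5-difluorophenyl in place of 2-ethoxyphenyl on a saturated chain carbon bound to a nitrogen on an aromatic ring. Two measured steps exist, and only one touches the same place. That one, a 2.1-fold lower number from compound 2 to compound 3 (0.33 log units; beyond the scatter), swapped a short chain for an aromatic ring and was modest. The other, a 5.5-fold higher number from compound 1 to compound 2 (0.74 log units; beyond the scatter), changed the group on a nitrogen on an aromatic ring, a different place, and was also modest. Going by the values given here, no measured step swaps one aromatic ring for another on this saturated chain carbon, so the guidance is indirect, and the two modest steps suggest that exchanging one ring for another is unlikely to move the number far.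

The step from compound 3 to compound 4 is therefore expected to be a 1.3-fold lower number from compound 3 to compound 4 (0.10 log units; within the scatter), that is, not clearly beyond the scatter. For compound 4 the estimated number in this assay is 12 nM, expected to lie between 4 nM and 40 nM.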

Compound 4, inhibition constant: 16.5 nM
Beside the measured number, compound 4's estimate is 1.4-fold (0.14 log units) below it, within the range that was stated.
By their numbers in this assay, from the lowest: compound 1; then compounds 3, 4 and 2 (each within the scatter of the next, the first and the last beyond it).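

In this assay, exchanging one aromatic ring for another on a saturated chain carbon bound to a nitrogen on an aromatic ring gives no clear difference, with a 1.1-fold higher number from compound 3 to compound 4 (0.04 log units; within the scatter), even though 2,5-difluorophenyl brings in two fluorine atoms and 2-ethoxyphenyl takes away the oxygen and its hydrogen-bond acceptor. Replacing the 2-fluoroethyl chain with the 2,5-difluorophenyl ring gives a 2.0-fold lower number from compound 2 to compound 4 (0.29 log units; within the scatter), so this chain-to-ring exchange stays inside the scatter, and a ring at this place cannot be taken as a firm improvement over that chain. The cyclobutyl group directly on the nitrogen still gives a clearly lower number than the 2,5-difluorobenzyl group, with a 2.8-fold higher number from compound 1 to compound 4 (0.45 log units; beyond the scatter), so neither ring tried here reaches the level of that small saturated ring.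

No measurement shown explains why the two rings give such similar numbers. As far as these compounds go, it remains open whether a benzyl ring carrying an amine or a carboxylic acid, or a longer chain between the nitrogen and the ring, would separate clearly from these values.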